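Leaving 2-nitrophenyl: compound 3 to compound 4

This account rests on a few compounds, and the source may have more. Where it says the series, first, only, none or still open, it means among the compounds named here.

Three compounds sharing one core have numbers in a functional assay on HepG2 cells (Homo sapiens) for antiproliferative activity, read by MTT assay, with a stated time of 48 h; a lower number here means a stronger inhibitor, a higher number a weaker inhibitor. Compound 1 `CC(=O)N1N=C(c2ccc3ccccc3c2)OC1c1ccc(Br)cc1` gives 2.08 ug/mL, and compound 2 `CC(=O)N1N=C(c2ccc3ccccc3c2)OC1c1cccc(F)c1` gives 1.86 ug/mL. The step between them is a 1.1-fold lower number from compound 1 to compound 2 (0.05 log units; within the scatter), so 4-bromophenyl and 3-fluorophenyl are not separated here. Compound 3 `CC(=O)N1N=C(c2ccc3ccccc3c2)OC1c1ccccc1[N+](=O)[O-]`, at 12.3 ug/mL, has the highest number of the three and is the weakest inhibitor in this assay. The two steps that reach it are a 5.9-fold higher number from compound 1 to compound 3 (0.77 log units; beyond the scatter) and a 6.6-fold higher number from compound 2 to compound 3 (0.82 log units; beyond the scatter).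

Compound 4 `CC(=O)N1N=C(c2ccc3ccccc3c2)OC1c1ccc(C)cc1` has 4-methylphenyl in place of 2-nitrophenyl on a saturated ring carbon. Among the measured compounds shown here, no measured compound carries 4-methylphenyl, so the data hold no direct comparison. The two modest steps to compound 3 are the closest evidence, read backwards: both compounds lacking 2-nitrophenyl stand lower. The closest match is compound 1, which has 4-bromophenyl on the same ring carbon and stands at 2.08 ug/mL. A step of similar size toward a lower number is therefore expected, slightly reduced to allow for the untested group. The expected step is a 4.1-fold lower number from compound 3 to compound 4 (0.61 log units; beyond the scatter). For compound 4 the estimated value is 3 ug/mL, with an expected range of 1.2 ug/mL to 8 ug/mL.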

Compound 4, half-maximal inhibitory concentration: 2.26 ug/mL
The estimate for compound 4 lay 1.3-fold (0.12 log units) above the measured number; low and high end bracket the measured number.
By their numbers in this assay, from the lowest: compounds 2, 1 and 4 (each within the scatter of the next); then compound 3.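

In this assay, the step to 4-methylphenyl is a 5.4-fold lower number from compound 3 to compound 4 (0.74 log units; beyond the scatter), so 2-nitrophenyl now stands apart from three different aryl groups on this saturated ring carbon, and one of those groups contains only carbon. Replacing bromo with methyl on the same aromatic carbon leaves the number unresolved, at a 1.1-fold higher number from compound 1 to compound 4 (0.04 log units; within the scatter), and 4-methylphenyl is not separated from 3-fluorophenyl either, at a 1.2-fold higher number from compound 2 to compound 4 (0.08 log units; within the scatter); halogen is therefore not required for compound 1 and compound 2 to stand apart from compound 3, since compound 4 keeps that separation without one. Among these four compounds, only compound 3 differs from the rest, and no measurement here speaks to the reason for that difference.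

The nitro group and its ring position change together in compound 3, so the series cannot yet tell which of the two goes with the higher number; 4-nitrophenyl and 2-methylphenyl would separate them. As far as these compounds go, how far the flat region extends also remains open, and 4-aminophenyl, 4-carboxyphenyl or 4-methoxyphenyl on the same ring carbon would test it.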